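Taking one chloro away from compound 1

The source may hold more compounds than are shown below. What is called first, only, known or untested is meant among the compounds shown, and "the series" means these compounds.

In a physicochemical assay for solubility, measured as kinetic solubility, with a stated time of 1 h, at pH 7.4 (on this read-out lower numbers stand for lower solubility and higher numbers for higher solubility), compound 1 `CC(=O)Nc1nc(-c2ccc(Cl)c(Cl)c2)cs1` gives < 1000 nM, which is a limit and not a number. Compound 2 `N#CCC(=O)Nc1nc(-c2ccc(Cl)c(Cl)c2)cs1` gives 57000 nM, and compound 3 `O=C(Nc1nc(-c2ccc(Cl)c(Cl)c2)cs1)c1cccnc1` gives 20000 nM. Compound 1 therefore stands lowest of the three.

Compound 4 `CC(=O)Nc1nc(-c2ccc(Cl)cc2)cs1` keeps the group on the carbonyl carbon of compound 1 and differs elsewhere: hydrogen in place of chloro on an aromatic carbon. In words, hydrogen sits in place of chloro on an aromatic carbon.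

For the measured compounds named here, no measured step makes this change. All three altered the group on the carbonyl carbon: an at least 57-fold higher number from compound 1 to compound 2 (1.75 log units; beyond the scatter), then an at least 20-fold higher number from compound 1 to compound 3 (1.30 log units; beyond the scatter), and a 2.9-fold lower number from compound 2 to compound 3 (0.45 log units; beyond the scatter). They bear on compound 4 only indirectly, by showing that a single change can carry compound 1 well away from its limit. With so little direct evidence, a smaller upward move is expected, and a result still at the limit would be no surprise. The expected step is an at least 2.0-fold higher number from compound 1 to compound 4 (0.30 log units; that floor lies within the scatter). For compound 4 the estimated value is 2000 nM, within an expected range of 400 nM to 10000 nM.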

Compound 4, solubility: 1000 nM
Estimate against measurement, compound 4: 2.0-fold (0.30 log units) above; low and high end bracket the measured number.
By their numbers in this assay, from the lowest: compound 4; then compound 3; then compound 2.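

In this assay, for the compounds shown here, compound 4 gives 1000 nM, the first reading for a change away from the carbonyl carbon: here it is on an aromatic carbon of the six-membered aromatic ring of carbon only, ortho to a chloro group. Replacing this chloro with hydrogen gives a number no lower from compound 1 to compound 4 (the limit leaves the size open), so the change did not bring the result clear of the limit, whereas the changes on the carbonyl carbon in compound 2 and compound 3 did. The size of the change cannot be read because compound 1 has only a limit and not a number: the limit of < 1000 nM in this assay, at which 1 of the 4 values shown sits.

On these data alone, what a fluoro, a methoxy or an amine would do on this aromatic carbon remains open, as does the effect of removing the other chloro. Also open, as far as these compounds go, is whether the cyanomethyl of compound 2 and the pyridin-3-yl of compound 3 would give similar numbers on the core of compound 4.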